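The source may report more compounds than this note shows. Statements on the series, on what has been measured and on what is new or still open speak of the compounds shown alone.

Measured so far:
- compound 1, `S=C(Nc1ccccc1)N1N=C(c2ccccc2)CC1c1ccc2c(c1)OCCO2`: 6630 nM
- compound 2, `CSc1ccc(C2=NN(C(=S)Nc3ccccc3)C(c3ccc4c(c3)OCCO4)C2)cc1`: > 200000 nM, a limit
- compound 3, `S=C(Nc1ccccc1)N1N=C(c2ccccc2Br)CC1c1ccc2c(c1)OCCO2`: > 200000 nM, a limit

Among the measured compounds shown here, in a functional assay on HT-29 cells (Homo sapiens) for antiproliferative activity, read by MTT assay, with a stated time of 48 h (on this read-out lower numbers stand for stronger inhibition of growth and higher numbers for weaker inhibition of growth), compound 1 gives 6630 nM, the only number in the set. For compound 2 the read-out in this assay is a limit, > 200000 nM. For compound 3 the read-out in this assay is likewise a limit, > 200000 nM. For the measured compounds named here, compound 1 thus stands alone as the one compound with a measured value, the other two sitting at the limit of > 200000 nM in this assay, at which 2 of the 3 values shown sit.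

The unmeasured compound 4 is `COc1cccc(C2=NN(C(=S)Nc3ccccc3)C(c3ccc4c(c3)OCCO4)C2)c1`. It differs from compound 1 by methoxy in place of hydrogen on an aromatic carbon, on the phenyl attached to the carbon with a double bond to nitrogen, the same phenyl that carries the changed group in compound 2 and compound 3.

Going by the values given here, two measured steps bear on this change. Adding a group to that phenyl gave an at least 30-fold higher number from compound 1 to compound 2 (1.47 log units; beyond the scatter) and an at least 30-fold higher number from compound 1 to compound 3 (1.47 log units; beyond the scatter). The comparison between the two substituted compounds, a step that the two limits leave unreadable from compound 2 to compound 3, cannot be read, so nothing separates the two substituents. In this assay a large step toward weaker inhibition is therefore expected for compound 4 as well, with a real chance that only a limit is returned. Compound 4 is estimated at 60000 nM, in the range 10000 nM to 200000 nM. The expected step is a 9.0-fold higher number from compound 1 to compound 4 (0.96 log units; beyond the scatter).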

Compound 4, concentration for 50% growth inhibition: 2920 nM
Compound 4: middle estimate off by 21-fold (1.31 log units), on the high side, and the stated range ends above it.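

In this assay, the phenyl on the carbon with a double bond to nitrogen proves able to carry a substituent without loss, with a 2.3-fold lower number from compound 1 to compound 4 (0.36 log units; beyond the scatter), so the collapse seen in the two earlier substituted compounds is not a general outcome of substituting this ring. The 3-methoxyphenyl group also separates clearly from both earlier rings, with an at least 68-fold lower number from compound 3 to compound 4 (1.83 log units; beyond the scatter) for the change from 2-bromophenyl and an at least 68-fold lower number from compound 2 to compound 4 (1.83 log units; beyond the scatter) for the change from 4-(methylsulfanyl)phenyl, although the step between those two earlier compounds cannot be read. The read-out on this ring therefore depends strongly on which substituted phenyl is present, and compound 2 and compound 3 go against any claim of a general gain from substitution.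

The three substituted rings differ in both the group and its place, so the compounds shown cannot separate the contribution of methoxy from that of its placement. From the compounds shown here alone, it also remains open whether a hydroxy group, an amine or a longer chain such as ethoxy on this phenyl would stay close to compound 4 or fall away as compound 2 and compound 3 do.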